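Propyl Amide to Cyanophenyl Amide: Toxicity Not Yet Known

The source may hold more compounds than are shown below. What is called first, only, known or untested is meant among the compounds shown, and "the series" means these compounds.

Compound 1 `CCCC(=O)Nc1ncc(-c2ccc(OC)cc2)n1C` gives > 100000 nM in a toxicity assay on THP-1 cells (Homo sapiens) for inhibition (a lower number here means that less compound is tolerated, a higher number that more compound is tolerated), a limit of the assay rather than a number.
Compound 2 `COc1ccc(-c2cnc(NC(=O)c3cccc([N+](=O)[O-])c3)n2C)cc1` gives > 100000 nM in this assay, again a limit.
Compound 3 `COc1ccc2c(c1)nc(NC(=O)c1ccc(F)cc1)n2C` gives > 100000 nM in this assay, again a limit.

Of the compounds shown here, three have been measured so far, and none of them has yielded a number: every value sits at the limit of the assay (the limit of > 100000 nM in this assay, at which 3 of the 3 values shown sit). For the measured compounds named here, compound 1 therefore stands exactly where compound 2 and compound 3 stand, with nothing to separate the three, and no step between measured compounds can be read from these values. The shared core, with its methoxyphenyl group and its amide-type nitrogen, is present in all of them, and only the group on the carbonyl carbon varies.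

Compound 4 `COc1ccc(-c2cnc(NC(=O)c3ccccc3C#N)n2C)cc1` has not been measured. It differs from compound 1 in one place: 2-cyanophenyl in place of propyl on a carbonyl carbon. The rest of the molecule is unchanged. Going by the values given here, no measured step resembles this change, and the three values give no direction to work from, since all of them are limits.

The step of a number no higher from compound 1 to compound 4 (the limit leaves the size open) is expected to be none beyond the scatter. Compound 4 is estimated at 100000 nM, within a range from 50000 nM to 300000 nM, most likely again reported as a limit.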

Compound 4, half-maximal cytotoxic concentration: > 100000 nM
Compound 4 gave a limit, no number; the forecaster's own chance of this, stated with the estimate: 85%; the middle value sits exactly at the limit.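

In this assay compound 4 gives > 100000 nM, a limit of the assay and not a number. Compound 1 also stands at a limit, so no step from compound 1 to compound 4 can be read: the limit of > 100000 nM in this assay, at which 4 of the 4 values shown sit.

The compounds shown leave open how much of each compound is tolerated, and whether the group on the carbonyl carbon makes any difference.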